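The source may report more compounds than this note shows. Statements on the series, on what has been measured and on what is new or still open speak of the compounds shown alone.

Measured compounds:
compound 1, `N#CC1=C(N)Oc2c(c3nc4ccccc4nc3c3ccccc23)C12C(=O)N(Cc1cnnn1-c1ccc(F)cc1)c1ccccc12`, in an ADME assay on L02 cells (Homo sapiens) for antiproliferative activity, read by MTT assay, with a stated time of 48 h (on this read-out higher numbers stand for weaker inhibition and lower numbers for stronger inhibition), compound 1 gives > 50000 nM, which is a limit of the assay and not a number.
compound 2, `N#CC1=C(N)Oc2c(c3nc4ccccc4nc3c3ccccc23)C12C(=O)N(Cc1cnnn1-c1cccc(Cl)c1)c1ccccc12`, in this assay compound 2 gives 35200 nM.

Going by the values given here, compound 2 stands as the only compound of the pair with a number in this assay; the other value shown is a limit, recorded as the limit of > 50000 nM in this assay, at which 1 of the 2 values shown sits. The step from the 4-fluorophenyl of compound 1 to the 3-chlorophenyl of compound 2 is an at least 1.4-fold lower number from compound 1 to compound 2 (0.15 log units; that floor lies within the scatter), a step whose floor lies within the scatter, so the two aryl groups on the aromatic nitrogen cannot be told apart on these numbers.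

Compound 3, `COc1ccc(-n2nncc2CN2C(=O)C3(C(C#N)=C(N)Oc4c3c3nc5ccccc5nc3c3ccccc43)c3ccccc32)cc1`, differs from compound 2 by 4-methoxyphenyl in place of 3-chlorophenyl on an aromatic nitrogen. Among the compounds with values here, the only measured step that bears on it is the one from compound 1 to compound 2, and that step was too small to separate its two compounds. Within the data shown here, no measured step therefore points in either direction for the change to 4-methoxyphenyl, and the expected step of a 1.1-fold higher number from compound 2 to compound 3 (0.06 log units; within the scatter) is none beyond the scatter. Compound 3 is estimated at 40000 nM in this assay, between 15000 nM and 100000 nM, with a real chance that the assay again reports only a limit.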

Compound 3, half-maximal inhibitory concentration: > 50000 nM
Compound 3 ended at the assay's limit (the forecaster's own chance of this, stated with the estimate: 45%); middle value at least 1.2-fold (0.09 log units) away from the limit.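

In this assay, the change to 4-methoxyphenyl on the aromatic nitrogen gives an at least 1.4-fold higher number from compound 2 to compound 3 (0.15 log units; that floor lies within the scatter), so a second step at this position fails to clear the scatter, this time with an aryl group that carries a hydrogen-bond acceptor. The step from compound 1 to compound 3 cannot be read, as the values of both compounds are limits of the assay and not numbers. Across the three aryl groups tried at this position, no step yet separates one group from another, and the read-out rests largely on a limit: the limit of > 50000 nM in this assay, at which 2 of the 3 values shown sit.

On these data alone, whether a group of another kind on this aromatic nitrogen, such as a phenyl ring bearing an amine or a carboxylic acid, or a longer alkyl chain in place of the aryl ring, would move the number beyond the scatter stays open. Also open, as far as these compounds go, is whether the true values of compound 1 and compound 3 lie close to the value of compound 2 or far from it in this assay.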